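This account rests on a few compounds, and the source may have more. Where it says the series, first, only, none or still open, it means among the compounds named here.

Measured compounds in this series:

Compound 1 `COc1ccc(-c2cc(C(=O)Nc3ccc(Oc4ccnc5cc(OCCCN6CCCCC6)c(OC)cc45)c(F)c3)c3ccccc3n2)cc1`: 1360 nM
Compound 2 `COc1cc2c(Oc3ccc(NC(=O)c4cc(-c5cccc(Cl)c5)nc5ccccc45)cc3F)ccnc2cc1OCCCN1CCC(C)CC1`: 580 nM
Compound 3 `COc1ccc(-c2cc(C(=O)Nc3ccc(Oc4ccnc5cc(OCCCN6CCCCC6)c(OC)cc45)c(F)c3)c3cc(F)ccc3n2)cc1`: 1100 nM

All three numbers come from a functional assay on U-87MG ATCC cells (Homo sapiens) for cytotoxicity, read by MTT assay, with a stated time of 72 h; on this read-out higher numbers stand for weaker inhibition and lower numbers for stronger inhibition. Compound 3 differs from compound 1 by fluoro in place of hydrogen on an aromatic carbon, and this step gave a 1.2-fold lower number from compound 1 to compound 3 (0.09 log units; within the scatter). How the core of compound 2 differs from that of compound 1 is not broken down here.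

Compound 4 `COc1cc2c(Oc3ccc(NC(=O)c4cc(-c5cccc(Cl)c5)nc5ccc(F)cc45)cc3F)ccnc2cc1OCCCN1CCC(C)CC1` has not been measured. It differs from compound 2 by fluoro in place of hydrogen on an aromatic carbon, which is the same change made from compound 1 to compound 3, at a place described in the same words. For compound 4 the expected step is a 1.2-fold lower number from compound 2 to compound 4 (0.06 log units; within the scatter), resting on the step of a 1.2-fold lower number from compound 1 to compound 3 (0.09 log units; within the scatter), which stayed within the scatter. Compound 4 is therefore estimated at 500 nM in this assay, with an expected range from 250 nM to 1000 nM.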

Compound 4, half-maximal inhibitory concentration: 110 nM
Beside the measured number, compound 4's estimate is 4.5-fold (0.66 log units) above it; measured number below the stated range.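

In this assay, fluoro in place of hydrogen on an aromatic carbon gave a 5.3-fold lower number from compound 2 to compound 4 (0.72 log units; beyond the scatter). Set beside the earlier step, this shows that the size of the change did not carry over unchanged from one core to the other: the same change on two cores in this assay, a 1.2-fold lower number (0.09 log units; within the scatter) from compound 1 to compound 3 and a 5.3-fold lower number (0.72 log units; beyond the scatter) from compound 2 to compound 4, 4.3-fold (0.63 log units) apart, beyond the scatter of two such steps

For the compounds shown here, this comparison rests on only two steps, so it does not show which difference between the two cores goes with the larger step, nor what size the step would take on a further core. Also open, as far as these compounds go, is how compound 2 would respond on the same aromatic carbon to a group other than fluoro, such as a nitrile or an amine.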